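Repositioning halogens on the aryl piperazine of compound 1

This account rests on a few compounds, and the source may have more. Where it says the series, first, only, none or still open, it means among the compounds named here.

Compound 1 `Nc1scc(CN2CCN(c3ccc(Cl)cc3F)CC2)c1C(=O)c1ccc(Cl)cc1` is the lower of the two numbers in hand. In a functional assay on CHO cells with adenosine receptor A1 (Homo sapiens) as the target, read by cAMP accumulation and immunoassay, with a stated time of 6 min, tested at 0.01 uM (on this read-out higher numbers stand for a weaker effect at the one concentration tested and lower numbers for a stronger effect), compound 1 gives -9.2%, while compound 2 `Nc1scc(CN2CCN(c3cc(F)ccc3F)CC2)c1C(=O)c1ccc(Cl)cc1` gives 3.1%. Among the compounds with values here, the one measured step, a number 12.3 percentage points higher from compound 1 to compound 2 (beyond the scatter), is the only guide for the untested compound 3 `Nc1scc(CN2CCN(c3ccc(F)c(Cl)c3)CC2)c1C(=O)c1ccc(Cl)cc1`. Compound 3 differs from compound 1 as follows: 3-chloro-4-fluorophenyl in place of 4-chloro-2-fluorophenyl on an amine nitrogen in a ring. The change to compound 2 swapped one halogen for another and moved the read-out by a modest amount; compound 3 instead keeps the same atoms and only moves them to other places on the ring. Within the data shown here, since the only known step is modest, the author expects for compound 3 a step of about a number 7.2 percentage points higher from compound 1 to compound 3 (within the scatter) in this assay, small and upward if anything. Compound 3 is therefore estimated at -2%, within -18% to 14%.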

Compound 3, a percentage reported as activity, at one concentration (the size of the read-out at that concentration, not a potency): 4.2%
Compound 3: the middle estimate sits 6.2 percentage points below what was measured; measured number inside the range.
By their numbers in this assay, from the lowest: compound 1; then compounds 2 and 3 (each within the scatter of the next).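

In this assay, moving the same halogens to other places on the ring still gives a number 13.4 percentage points higher from compound 1 to compound 3 (beyond the scatter), a step of the same modest class as a number 12.3 percentage points higher from compound 1 to compound 2 (beyond the scatter), so on this amine nitrogen in a ring the arrangement of the halogens alone is enough to shift the read-out beyond the scatter. The other new step, a number 1.1 percentage points higher from compound 2 to compound 3 (within the scatter), leaves 3-chloro-4-fluorophenyl and 2,5-difluorophenyl indistinguishable here, and of the three aryl groups only 4-chloro-2-fluorophenyl stands apart from both others. Nothing at hand explains this difference.

The compounds shown leave open whether the chlorine or the fluorine of 4-chloro-2-fluorophenyl matters more. They also leave open how an unsubstituted phenyl, or an aryl group carrying methoxy or a nitrile, would read on this nitrogen.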